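Working notes: cytotoxicity within one amide-terminated ester series

The source may report more compounds than this note shows. Statements on the series, on what has been measured and on what is new or still open speak of the compounds shown alone.

Measured so far in an ADME assay on HeLa cells (Homo sapiens) for cytotoxicity, read by MTT assay; on this read-out higher numbers stand for weaker inhibition and lower numbers for stronger inhibition:
compound 1 `COC(=O)[C@@H](NC(=O)CCC(=O)Oc1ccc(C[C@H]2C(=O)OC[C@@H]2Cc2ccc(OC)c(OC)c2)cc1OC)c1c[nH]c2ccccc12` gives >= 600000 nM; this is a limit of the assay, not a number.
compound 2 `COC(=O)CNC(=O)CCC(=O)Oc1ccc(C[C@H]2C(=O)OC[C@@H]2Cc2ccc(OC)c(OC)c2)cc1OC` gives 179000 nM.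
compound 3 `CCN1CCN(C(=O)CCC(=O)Oc2ccc(C[C@H]3C(=O)OC[C@@H]3Cc3ccc(OC)c(OC)c3)cc2OC)CC1` gives 190000 nM.

Among the two plain numbers, compound 3 stands highest, with compound 2 nearest; the step of a 1.1-fold higher number from compound 2 to compound 3 (0.03 log units; within the scatter) sits within the scatter, so the two are not separable. Compound 1 sits at the limit (the limit of >= 600000 nM in this assay, at which 1 of the 3 values shown sits).

Compound 4 `COC(=O)[C@H](CCSC)NC(=O)CCC(=O)Oc1ccc(C[C@H]2C(=O)OC[C@@H]2Cc2ccc(OC)c(OC)c2)cc1OC` is the next member. Relative to compound 3 the change is (1-(methoxycarbonyl)-3-(methylsulfanyl)propyl)amino in place of 4-ethylpiperazin-1-yl on a carbonyl carbon.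

The step that bears most directly on this is an at least 3.3-fold lower number from compound 1 to compound 2 (0.52 log units; beyond the scatter): removing the 1H-indol-3-yl substituent from the saturated chain carbon bound to the amide-type nitrogen brought the number down from the limit to a plain value. Compound 4 restores a substituent on that carbon, 1-(methoxycarbonyl)-3-(methylsulfanyl)propyl, though not the 1H-indol-3-yl of compound 1. The step of a 1.1-fold higher number from compound 2 to compound 3 (0.03 log units; within the scatter) shows that exchanging the amide partner itself moves little. A modest rise in the number is therefore expected in this assay, with a real chance that only a limit is returned.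

Compound 4 is expected at 320000 nM, within 160000 nM to 650000 nM.
The expected step is a 1.7-fold higher number from compound 3 to compound 4 (0.23 log units; within the scatter).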

Compound 4, half-maximal inhibitory concentration: 199000 nM
Compound 4: the middle estimate sits 1.6-fold (0.21 log units) above what was measured; measured number inside the range.
By their numbers in this assay, from the lowest: compounds 2, 3 and 4 (each within the scatter of the next). At a limit, above all of these: compound 1.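

In this assay, 2-(methylsulfanyl)ethyl on the saturated chain carbon bound to an amide-type nitrogen and a carbonyl carbon cannot be separated from hydrogen there (a 1.1-fold higher number from compound 2 to compound 4 (0.05 log units; within the scatter)), so a substituent on this carbon does not in itself bring the read-out to the limit, and the open-chain (1-(methoxycarbonyl)-3-(methylsulfanyl)propyl)amino on the carbonyl carbon cannot be separated from the ring of 4-ethylpiperazin-1-yl either (a 1.0-fold higher number from compound 3 to compound 4 (0.02 log units; within the scatter)). The 2-(methylsulfanyl)ethyl group in place of 1H-indol-3-yl on the same carbon gives a step beyond the scatter (an at least 3.0-fold lower number from compound 1 to compound 4 (0.47 log units; beyond the scatter)), which sets the 1H-indol-3-yl compound apart from a second substituted member as well as from the unsubstituted one. Compound 1 remains a limit and not a number, so this step gives only a bound on the size of the difference: the limit of >= 600000 nM in this assay, at which 1 of the 4 values shown sits.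

The compounds shown leave open whether the limit goes with the 1H-indol-3-yl group itself or with any aromatic ring on this carbon, which a phenyl or benzyl group there would test. They also leave open whether the methyl ester matters, which the corresponding carboxylic acid would address.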